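This account rests on a few compounds, and the source may have more. Where it says the series, first, only, none or still open, it means among the compounds named here.

Measured so far, in a functional assay on HT-29 cells (Homo sapiens) for inhibition, read by MTT assay, with a stated time of 72 h; a lower number here means a stronger inhibitor, a higher number a weaker inhibitor:
compound 1, `COc1cc2c(Oc3ccc(NC(=O)c4nn(-c5ccccc5C)c(=O)cc4C)cc3F)ccnc2cc1OCCCN1CCC(C)CC1`, 2810 nM
compound 2, `COc1cc2c(Oc3ccc(NC(=O)c4nn(-c5ccccc5C)c(=O)cc4C)cc3F)ccnc2cc1OCCCN1CCN(C)CC1`, 3790 nM
compound 3, `COc1cc2c(Oc3ccc(NC(=O)c4nn(-c5ccccc5OC(F)(F)F)c(=O)cc4C)cc3F)ccnc2cc1OCCCN1CCC(C)CC1`, 250 nM

Compound 2 differs from compound 1 by 4-methylpiperazin-1-yl in place of 4-methylpiperidin-1-yl on a saturated chain carbon, three bonds along the chain from an oxygen on an aromatic ring, and this gave a 1.3-fold higher number from compound 1 to compound 2 (0.13 log units; within the scatter). Compound 3 differs from compound 1 in its core by trifluoromethoxy in place of methyl on an aromatic carbon, which gave an 11-fold lower number from compound 1 to compound 3 (1.05 log units; beyond the scatter).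

Compound 4, `COc1cc2c(Oc3ccc(NC(=O)c4nn(-c5ccccc5OC(F)(F)F)c(=O)cc4C)cc3F)ccnc2cc1OCCCN1CCN(C)CC1`, is not yet measured. It differs from compound 3 by 4-methylpiperazin-1-yl in place of 4-methylpiperidin-1-yl on a saturated chain carbon, three bonds along the chain from an oxygen on an aromatic ring, the same change as between compound 1 and compound 2, made at the same place.

For compound 4 the step of a 1.3-fold higher number from compound 3 to compound 4 (0.12 log units; within the scatter) is expected to be small because a 1.3-fold higher number from compound 1 to compound 2 (0.13 log units; within the scatter) was within the scatter. On that basis, in this assay compound 4 is estimated at 330 nM, with a likely range from 150 nM to 700 nM.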

Compound 4, half-maximal inhibitory concentration: 180 nM
Compound 4: the middle estimate sits 1.8-fold (0.26 log units) above what was measured; low and high end bracket the measured number.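

In this assay, 4-methylpiperazin-1-yl in place of 4-methylpiperidin-1-yl gives a 1.4-fold lower number from compound 3 to compound 4 (0.14 log units; within the scatter), so this swap again stays within the scatter, and the two cores agree: the same change on two cores in this assay, a 1.3-fold higher number (0.13 log units; within the scatter) from compound 1 to compound 2 and a 1.4-fold lower number (0.14 log units; within the scatter) from compound 3 to compound 4, 1.9-fold (0.27 log units) apart, within the scatter of two such steps. Trifluoromethoxy in place of methyl, now read with the piperazine in place, gives a 21-fold lower number from compound 2 to compound 4 (1.32 log units; beyond the scatter), and this large step also carries over: the same change on two cores in this assay, an 11-fold lower number (1.05 log units; beyond the scatter) from compound 1 to compound 3 and a 21-fold lower number (1.32 log units; beyond the scatter) from compound 2 to compound 4, 1.9-fold (0.27 log units) apart, within the scatter of two such steps. These two pairs show that each change behaves alike on these two cores, but they do not show that it would do so on any other core, or why the trifluoromethoxy step is large.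

The compounds shown leave open how a morpholine, a dimethylamine or a longer chain would behave in place of the present chain end. They also leave open whether a methoxy group or a chlorine atom could stand in for trifluoromethoxy.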